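A few compounds are considered here, and "the series" means these few. Any claim that something is new, unique, unknown or untested is made for them only; others in the source may bear on it.

Compound 3 `Cc1nn(C)c(Oc2ccc(Cl)cc2)c1/C=N\CCCCCCOc1cc2oc(=O)cc(C)c2cc1Cl` gives the lowest number of the three compounds measured in a functional assay on HepG2 cells (Homo sapiens) for antiproliferative activity, read by MTT assay, with a stated time of 72 h (on this read-out higher numbers stand for weaker inhibition and lower numbers for stronger inhibition), at 2960 nM. Compound 2 `Cc1ccc(Oc2c(/C=N\CCCCCOc3cc4oc(=O)cc(C)c4cc3Cl)c(C)nn2C)cc1` stands nearest to it, giving 10300 nM in this assay, and compound 1 `Cc1nn(C)c(Oc2cccc(F)c2)c1/C=N\CCCCCOc1cc2oc(=O)cc(C)c2cc1Cl` stands furthest, giving 13400 nM in this assay; both gaps lie beyond the scatter. Among the measured compounds shown here, compounds 1 and 2 each differ from compound 3 in more than one place, so their values show only that compound 3 sits apart from both, not what any single change contributes.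

Compound 4 `Cc1nn(C)c(Oc2ccc(OC(F)(F)F)cc2)c1/C=N\CCCCCCOc1cc2oc(=O)cc(C)c2cc1Cl` differs from compound 3 by trifluoromethoxy in place of chloro on an aromatic carbon. For the measured compounds named here, the only measured step that changes a single place, a 1.3-fold lower number from compound 1 to compound 2 (0.11 log units; within the scatter), exchanges one aryl group for another on an oxygen on an aromatic ring and stays within the scatter. Going by the values given here, that step does not involve the same groups, so its bearing on the present change is indirect, but it is the only guide available, and it suggests that such exchanges on this aryl group move the number little. Compound 4 is therefore expected to give about 3500 nM in this assay, with a range from 1200 nM to 10000 nM. The expected step is a 1.2-fold higher number from compound 3 to compound 4 (0.07 log units; within the scatter), which is not beyond the scatter.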

Compound 4, half-maximal inhibitory concentration: 8160 nM
Beside the measured number, compound 4's estimate is 2.3-fold (0.37 log units) below it; low and high end bracket the measured number.
By their numbers in this assay, from the lowest: compound 3; then compounds 4, 2 and 1 (each within the scatter of the next).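

In this assay, the position para to a large group on the aryl ring proves sensitive to its substituent: with trifluoromethoxy in place of chloro, the result is a 2.8-fold higher number from compound 3 to compound 4 (0.44 log units; beyond the scatter). The earlier single-place step, a 1.3-fold lower number from compound 1 to compound 2 (0.11 log units; within the scatter), exchanged one aryl group for another and stayed within the scatter, so it gave no sign that a change on this aryl group could shift the number beyond the scatter; this single pair now shows that it can, with chloro the better of the two groups here. The change also brings in a hydrogen-bond acceptor that chloro does not have, but no measurement shown ties the step to that or to any other feature of either group.

The compounds shown leave open whether a simple methoxy, an amine or a carboxylic acid at this place would give a number nearer that of compound 3 or that of compound 4. They also leave open whether the same exchange would give a step of similar size on the chain carried by compound 1 and compound 2, or on a longer chain.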